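The source may report more compounds than this note shows. Statements on the series, on what has been measured and on what is new or still open speak of the compounds shown alone.

Measured so far in a toxicity assay on MCF-10A cells (Homo sapiens) for cytotoxicity, read by MTT assay, with a stated time of 48 h; on this read-out lower numbers stand for stronger inhibition and higher numbers for weaker inhibition:
compound 1 `O=C(/C=C/c1ccc2c(c1)B(O)OC2)c1ccco1`: 7400 nM
compound 2 `O=C(/C=C/c1ccc2c(c1)B(O)OC2)c1ccc(Br)cc1`: 27800 nM
compound 3 `O=C(/C=C/c1ccc2c(c1)B(O)OC2)c1ccc(I)cc1`: > 100000 nM, which is a limit of the assay and not a number.

Compound 3 therefore shows the weakest inhibition of the three, and only a limit is known for it, since its value sits at the limit of > 100000 nM in this assay, at which 1 of the 3 values shown sits. The measured steps all run toward weaker inhibition: a 3.8-fold higher number from compound 1 to compound 2 (0.57 log units; beyond the scatter), an at least 13-fold higher number from compound 1 to compound 3 (1.13 log units; beyond the scatter), and an at least 3.5-fold higher number from compound 2 to compound 3 (0.55 log units; beyond the scatter). Compound 4 `Cc1ccc(C(=O)/C=C/c2ccc3c(c2)B(O)OC3)cc1` differs from compound 3 by methyl in place of iodo on an aromatic carbon. Within the data shown here, no measured step exchanges a halogen for a methyl on this ring; the closest comparison is the halogen exchange from compound 2 to compound 3, which moved the number beyond the scatter. Because compound 3 stands only at the limit of > 100000 nM in this assay, at which 1 of the 3 values shown sits, the size of the step to compound 4 cannot be fixed from that side, and a return toward the range of compound 2 is as plausible as staying at the limit. Compound 4 is expected to give about 45000 nM in this assay, within 12000 nM to 150000 nM. The step this estimate implies is expected to read an at least 2.2-fold lower number from compound 3 to compound 4 (0.34 log units; beyond the scatter).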

Compound 4, half-maximal inhibitory concentration: 8300 nM
For compound 4 the middle estimate is 5.4-fold (0.73 log units) above the measured one, outside the stated range (below it).
By their numbers in this assay, from the lowest: compounds 1 and 4 (each within the scatter of the next); then compound 2. At a limit, above all of these: compound 3.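

In this assay, among these compounds, the earlier compounds held only bromo or iodo on the aromatic carbon para to a large group, and methyl at that place turns the trend back: an at least 12-fold lower number from compound 3 to compound 4 (1.08 log units; beyond the scatter), and a 3.3-fold lower number from compound 2 to compound 4 (0.52 log units; beyond the scatter). The value of compound 3 is a limit and not a number: the limit of > 100000 nM in this assay, at which 1 of the 4 values shown sits. Exchanging the whole group on the carbonyl carbon changes little here, a 1.1-fold higher number from compound 1 to compound 4 (0.05 log units; within the scatter), so a phenyl ring there does not by itself bring the higher numbers of compound 2 and compound 3.

From the compounds shown here alone, it remains open whether an amine, a carboxylic acid or a longer chain at this place would read like methyl or like the halogens. Whether the same order would hold in other cell types also stays unanswered.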